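Swapping the Amide Aryl Group Across Two Related Cores

This account rests on a few compounds, and the source may have more. Where it says the series, first, only, none or still open, it means among the compounds named here.

Compound 1 `CCCCCCCCCCCCn1nnc(C(NC(=O)c2cccc([N+](=O)[O-])c2)c2ccccc2)n1` in an assay on microsomes from liver for inhibition of sterol O-acyltransferase 1 (Rattus norvegicus); on this read-out higher numbers stand for weaker inhibition and lower numbers for stronger inhibition: 80 nM
Compound 2 `CCCCCCCCCCCCn1nnc(C(NC(=O)c2ccccc2C(F)(F)F)c2ccccc2)n1` in this assay: 120 nM
Compound 3 `CCCCCCCCCCCCn1nnnc1C(NC(=O)c1cccc([N+](=O)[O-])c1)c1ccccc1` in this assay: 190 nM

The change 2-(trifluoromethyl)phenyl in place of 3-nitrophenyl on a carbonyl carbon gives a 1.5-fold higher number from compound 1 to compound 2 (0.18 log units; within the scatter). Compound 3 shares its atoms with compound 1 but joins them differently; the difference between the two cores is not broken down here. Against compound 1, compound 3 stands at a higher number in this assay, whereas against compound 2 it lies within the scatter.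

Compound 4 `CCCCCCCCCCCCn1nnnc1C(NC(=O)c1ccccc1C(F)(F)F)c1ccccc1` is the as yet unmeasured counterpart of compound 3, made by 2-(trifluoromethyl)phenyl in place of 3-nitrophenyl on a carbonyl carbon, the same change at the same place as in the first pair. The step from compound 3 to compound 4 is expected to be a 1.5-fold higher number from compound 3 to compound 4 (0.18 log units; within the scatter), an expectation that rests on a 1.5-fold higher number from compound 1 to compound 2 (0.18 log units; within the scatter) in the other core. Compound 4 is therefore estimated at 290 nM, with a likely range from 130 nM to 650 nM.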

Compound 4, half-maximal inhibitory concentration: 350 nM
Beside the measured number, compound 4's estimate is 1.2-fold (0.08 log units) below it; measured number inside the range.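

In this assay, the change from 3-nitrophenyl to 2-(trifluoromethyl)phenyl on the carbonyl carbon gives a 1.8-fold higher number from compound 3 to compound 4 (0.27 log units; within the scatter). Both steps lie within the scatter, so neither shows on its own that the change moves the number at all, and two cores cannot show that it would carry to a further core. What the two pairs do show is that the change behaves alike on these two cores, with no difference between them that can be told apart: the same change on two cores in this assay, a 1.5-fold higher number (0.18 log units; within the scatter) from compound 1 to compound 2 and a 1.8-fold higher number (0.27 log units; within the scatter) from compound 3 to compound 4, 1.2-fold (0.09 log units) apart, within the scatter of two such steps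

The compounds shown leave open whether the same agreement would hold for other groups on the amide aryl ring, such as an amine or a carboxylic acid. They also leave open whether it would hold with a shorter chain on the core.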